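The source may report more compounds than this note shows. Statements on the series, on what has been measured and on what is new or still open speak of the compounds shown alone.

Compound 1 `O=C(Nc1cc(Sc2ncn[nH]2)c(O)c2ccccc12)c1ccc([N+](=O)[O-])cc1` stands highest of the three measured compounds in an assay on isolated protein for inhibition of RAC-alpha serine/threonine-protein kinase (Homo sapiens), read by fluorescence, with a stated time of 30 min, tested at 10 uM (on this read-out higher numbers stand for more inhibition at the one concentration tested (going by the name of the read-out) and lower numbers for less inhibition), giving 37.3%. Compound 3 `O=C(Nc1cc(Sc2ncnc3nc[nH]c23)c(O)c2ccccc12)c1ccc(Cl)cc1` gives 21.7% and compound 2 `Cc1nnc(Sc2cc(NC(=O)c3ccc(Cl)cc3)c3ccccc3c2O)s1` gives 8.48%. For the measured compounds named here, the only single-place step among them, a number 13.2 percentage points higher from compound 2 to compound 3 (beyond the scatter), concerns the group on the sulfur and not the amide-linked aryl ring. Compound 4 `COc1cccc(C(=O)Nc2cc(Sc3ncn[nH]3)c(O)c3ccccc23)c1` differs from compound 1 by 3-methoxyphenyl in place of 4-nitrophenyl on a carbonyl carbon. Going by the values given here, no measured step bears on this change: compound 1 and compound 2 differ in two places, so their values show only that compound 2 lies lower than compound 1. With nothing comparable to lean on, the change is expected to leave compound 4 near or somewhat below compound 1, an expected step of a number 10.3 percentage points lower from compound 1 to compound 4 (beyond the scatter). Compound 4 is therefore estimated at 27%, in a range from 8% to 48%.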

Compound 4, a percentage reported as inhibition, at one concentration (the size of the read-out at that concentration, not a potency): 19.4%
Estimate against measurement, compound 4: 7.6 percentage points above; the measured number falls inside the stated range.
By their numbers in this assay, from the lowest: compound 2; then compounds 4 and 3 (each within the scatter of the next); then compound 1.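

In this assay, 3-methoxyphenyl in place of 4-nitrophenyl on a carbonyl carbon gives a number 17.9 percentage points lower from compound 1 to compound 4 (beyond the scatter) and leaves the group on the sulfur unchanged. This is the first step shown at this position, and it shows that the read-out responds to the aryl group carried there. No available measurement accounts for the step.

The compounds shown do not separate the identity of the ring's substituent from its place on the ring. They also leave open how an amine or a carboxylic acid on this ring would read, and whether the step would hold with another group on the sulfur.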